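Compound 3: one inverted stereocentre, little change expected

A few compounds are considered here, and "the series" means these few. Any claim that something is new, unique, unknown or untested is made for them only; others in the source may bear on it.

- compound 1 `O=C(CCC(F)(F)C(F)(F)C(F)(F)C(F)(F)C(F)(F)C(F)(F)C(F)(F)C(F)(F)F)NCCCCCCCCCN[C@@H]1[C@H](O)[C@@H](O)[C@H](O)[C@H]2COC(=O)N21` gives 152000 nM as a number
- compound 2 `O=C(CCC(F)(F)C(F)(F)C(F)(F)C(F)(F)F)NCCCCCCCCCN[C@@H]1[C@H](O)[C@@H](O)[C@@H](O)[C@H]2COC(=O)N21` gives > 200000 nM as a limit

Among the measured compounds shown here, in an ADME assay on THP-1 cells (Homo sapiens) for cytotoxicity, read by MTT assay, with a stated time of 72 h (on this read-out higher numbers stand for an effect only at larger amounts of compound and lower numbers for an effect already at smaller amounts), compound 1, at 152000 nM, holds the only actual number, so it cannot yet be ranked against another measured value. Compound 2 gives only a limit, > 200000 nM, and not a number.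

Compound 3 `O=C(CCC(F)(F)C(F)(F)C(F)(F)C(F)(F)C(F)(F)C(F)(F)C(F)(F)C(F)(F)F)NCCCCCCCCCN[C@@H]1[C@H](O)[C@@H](O)[C@@H](O)[C@H]2COC(=O)N21` has not yet been measured. Its structure departs from compound 1 as follows: the two compounds have the same atoms and bonds and differ only in configuration as drawn: 1 of 5 stereo elements differ; a stereocentre at a saturated ring carbon is drawn R in compound 1 and S in compound 3. In short, a stereocentre at a saturated ring carbon is drawn R in compound 1 and S in compound 3. For the measured compounds named here, no measured pair shows the size of such a change, so the expectation rests on compound 1 and its 152000 nM value. The expected step is a 1.1-fold higher number from compound 1 to compound 3 (0.02 log units; within the scatter), which would be none beyond the scatter. For compound 3 the estimated value is 160000 nM, with an expected range from 80000 nM to 300000 nM in this assay here.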

Compound 3, half-maximal effective concentration: 124000 nM
Beside the measured number, compound 3's estimate is 1.3-fold (0.11 log units) above it; the measured number falls inside the stated range.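

In this assay, inverting this one stereocentre at a saturated ring carbon gives a 1.2-fold lower number from compound 1 to compound 3 (0.09 log units; within the scatter), the first measured size for a change of this kind. The step lies within the scatter, so the drawn configuration at this carbon does not separate the two compounds on this read-out. The comparison bears on configuration alone, and the pair allows this for one reason: the fact that compounds 1 and 3 differ only in the configuration as drawn.

Compound 2 offers only a limit, > 200000 nM, so it gives no number to set against the others. Still open, on these data alone, is whether inverting any of the other stereocentres would stay equally within the scatter, and what a plain hydrocarbon chain in place of the fluorinated chain would do on the same core.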